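The source may report more compounds than this note shows. Statements on the series, on what has been measured and on what is new or still open speak of the compounds shown alone.

Three compounds have been measured in a functional assay on MCF7 cells (Homo sapiens) for cytotoxicity, read by sulforhodamine B assay; a higher number here means a weaker inhibitor, a lower number a stronger inhibitor:

Compound 1, `C=C1[C@@H](OC(C)=O)C[C@@H]2[C@](C)(CO[Si](C)(C)C(C)(C)C)[C@H](OC(C)=O)CC[C@@]2(C)[C@@H]1C[C@@H](Nc1ccccc1F)C1=CCOC1=O`, gives 2930 nM.
Compound 2, `C=C1[C@@H](OC(C)=O)C[C@@H]2[C@](C)(CO[Si](C)(C)C(C)(C)C)[C@H](OC(C)=O)CC[C@@]2(C)[C@@H]1C[C@@H](Nc1ccc(OC)cc1)C1=CCOC1=O`, gives 4280 nM.
Compound 3, `C=C1[C@@H](OC(C)=O)C[C@@H]2[C@](C)(CO[Si](C)(C)C(C)(C)C)[C@H](OC(C)=O)CC[C@@]2(C)[C@@H]1C[C@@H](Nc1ccc(C(=O)O)cc1)C1=CCOC1=O`, gives 3990 nM.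

Compound 3 sits among these three numbers without any gap beyond the scatter: the step of a 1.1-fold lower number from compound 2 to compound 3 (0.03 log units; within the scatter) and the step of a 1.4-fold higher number from compound 1 to compound 3 (0.13 log units; within the scatter) are both small, as is the step of a 1.5-fold higher number from compound 1 to compound 2 (0.16 log units; within the scatter). Across the set, exchanging the group on the amine nitrogen has not moved the read-out in this assay by more than the usual spread.

Compound 4, `C=C1[C@@H](OC(C)=O)C[C@@H]2[C@](C)(CO[Si](C)(C)C(C)(C)C)[C@H](OC(C)=O)CC[C@@]2(C)[C@@H]1C[C@@H](Nc1ccc(F)cc1)C1=CCOC1=O`, has not yet been measured. It differs from compound 3 as follows: fluoro in place of carboxy on an aromatic carbon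

Among the measured compounds shown here, the steps that bear on this change are the step of a 1.1-fold lower number from compound 2 to compound 3 (0.03 log units; within the scatter), where one group on the same aromatic carbon replaced another, and the steps of a 1.5-fold higher number from compound 1 to compound 2 (0.16 log units; within the scatter) and a 1.4-fold higher number from compound 1 to compound 3 (0.13 log units; within the scatter), where the whole group on the amine nitrogen was exchanged. All three stayed within the scatter. On that basis the step of a 1.1-fold lower number from compound 3 to compound 4 (0.04 log units; within the scatter) is expected to be no larger than the scatter, in no particular direction. Compound 4 is therefore estimated at 3600 nM in this assay, with a range from 1700 nM to 7500 nM.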

Compound 4, half-maximal inhibitory concentration: 4340 nM
For compound 4 the middle estimate is 1.2-fold (0.08 log units) below the measured one; the measured number falls inside the stated range.
By their numbers in this assay, from the lowest: compounds 1, 3, 2 and 4 (each within the scatter of the next).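

In this assay, fluoro in place of carboxy on the aromatic carbon para to a large group gives a 1.1-fold higher number from compound 3 to compound 4 (0.04 log units; within the scatter), so removing the carboxy group, with its hydrogen-bond donor and acceptor, for a single fluorine atom with neither leaves the read-out within the scatter. Fluoro in place of methoxy at the same carbon gives a 1.0-fold higher number from compound 2 to compound 4 (0.01 log units; within the scatter), which means that three different groups have now been compared at this position, where the earlier compounds offered only two, and none of the steps among them exceeds the scatter. Among the compounds shown here, the exchange of 2-fluorophenyl for 4-fluorophenyl on the amine nitrogen gives a 1.5-fold higher number from compound 1 to compound 4 (0.17 log units; within the scatter), the first comparison here in which the same substituent stands at two places on the ring, and this step also stays within the scatter. No measurement available here offers an explanation for these results.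

The compounds shown leave open whether an amine or a longer alkyl chain on this aromatic carbon would also stay within the scatter. They also cannot show what the read-out would be with an alkyl chain in place of the whole aromatic ring on the amine nitrogen, or with changes elsewhere on the shared core.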